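This account rests on a few compounds, and the source may have more. Where it says the series, first, only, none or still open, it means among the compounds named here.

Compound 1 `CS(=O)(=O)Oc1c(C(=O)NCc2ccc(F)cc2)nc(Br)c2cccnc12` is the reference point of this note. In a functional assay on HCT-116 cells (Homo sapiens) for cytotoxicity, read by MTT assay, with a stated time of 72 h (a lower number here means a stronger inhibitor, a higher number a weaker inhibitor), compound 1 gives > 20000 nM, a limit of the measurement rather than a number, as recorded in the limit of > 20000 nM in this assay, at which 1 of the 3 values shown sits. Two other members of the series carry long alkylamino chains on the shared core. Compound 2 `CS(=O)(=O)NCCCCCCN(c1nc(C(=O)NCc2ccc(F)cc2)c(O)c2ncccc12)S(C)(=O)=O` gives 4000 nM in this assay. Compound 3 `O=CNCCCCCCNc1nc(C(=O)NCc2ccc(F)cc2)c(O)c2ncccc12` gives 6000 nM in this assay, and the two values lie within the usual scatter of each other. The unmeasured compound 4 `CN(C)CCCNc1c(C(=O)NCc2ccc(F)cc2)nc(Br)c2cccnc12` differs from compound 1 at one site, ((3-(dimethylamino)propyl)amino in place of (methylsulfonyl)oxy on an aromatic carbon). Among the measured compounds shown here, no measured step joins compound 1 to compound 4, so the expectation rests on the values shown for compound 2 and compound 3, which place aminoalkyl-bearing members at measurable values. The expected step, an at least 4.0-fold lower number from compound 1 to compound 4 (0.60 log units; beyond the scatter), is toward stronger inhibition in this assay and beyond the scatter. Compound 4 is estimated at 5000 nM in this assay, with a range from 1500 nM to 20000 nM.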

Compound 4, half-maximal inhibitory concentration: > 10000 nM
Compound 4: no number, only a limit; the forecaster's own chance of this, stated with the estimate: 25%; middle value at least 2.0-fold (0.30 log units) from the limit.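

Among the compounds shown here, no step from compound 1 to compound 4 can be read in this assay; each of the two compounds carries only a limit of the measurement. Still open, on these data alone, is how far (3-(dimethylamino)propyl)amino in place of (methylsulfonyl)oxy on an aromatic carbon moves the value in this assay.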